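A few compounds are considered here, and "the series" means these few. Any claim that something is new, unique, unknown or untested is made for them only; others in the source may bear on it.

Measured so far in a physicochemical assay for solubility, read by HPLC, using the shake flask method, measured as kinetic solubility, with a stated time of 2 h, at pH 7.4; on this read-out lower numbers stand for lower solubility and higher numbers for higher solubility:
compound 1 `Cc1cc(Nc2ccccn2)n2nc(C)c(-c3ccccc3)c2n1`: < 5000 nM
compound 2 `Cc1cc(NCc2ccccn2)n2ncc(-c3ccccc3C)c2n1`: < 5000 nM

Compound 1 stands at a limit of the assay with < 5000 nM, not at a number. Compound 2 likewise sits at a limit of the assay with < 5000 nM. Both readings fall under (the limit of < 5000 nM in this assay, at which 2 of the 2 values shown sit), so nothing shown separates compound 1 from compound 2, and no step between measured compounds can be read from them.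

Compound 3 `Cc1cc(NCC2CCCCN2)n2nc(C)c(-c3ccccc3)c2n1` is not yet measured. It differs from compound 1 in one place: (piperidin-2-yl)methyl in place of pyridin-2-yl on a nitrogen on an aromatic ring. Among the compounds with values here, with no measured step to lean on, the expectation rests on the structural change alone. The step from compound 1 to compound 3 in this assay is expected to be a rise beyond the usual scatter, an at least 4.0-fold higher number from compound 1 to compound 3 (0.60 log units; beyond the scatter). Compound 3 is therefore estimated at 20000 nM, within a range from 4000 nM to 150000 nM, while a reading that again stops at a limit of the assay cannot be excluded.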

Compound 3, solubility: 189000 nM
Compound 3: middle estimate off by 9.5-fold (0.98 log units), on the low side; the whole stated range lies below it.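

In this assay the place on the nitrogen on an aromatic ring tolerates a change with a large effect on the read-out: (piperidin-2-yl)methyl in place of pyridin-2-yl gives an at least 37-fold higher number from compound 1 to compound 3 (1.57 log units; beyond the scatter). Compound 3 is the first reading shown that is a number, and the step is only a lower bound because compound 1 rests at a limit of the assay: (the limit of < 5000 nM in this assay, at which 2 of the 3 values shown sit). The change swaps an aromatic ring for a non-aromatic one and brings in a hydrogen-bond donor, and this single step does not separate those parts.

Still open, as far as these compounds go, is whether a morpholine, an open-chain amine or a carboxylic acid on this nitrogen would give a step of similar size. Also open, from the compounds shown here alone, is whether the non-aromatic ring alone, as a piperidin-4-yl directly on the nitrogen, would do the same.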